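Hydroxyphenyl for Bromophenyl on the Pyrazoline Core

This account rests on a few compounds, and the source may have more. Where it says the series, first, only, none or still open, it means among the compounds named here.

Measured compounds: compound 1 `CC(C)(C)C1=NN(c2ccc(Cl)cc2Cl)C(c2ccc(O)cc2)C1` gives 71%; compound 2 `CC(C)(C)C1=NN(c2ccc(F)c(Cl)c2)C(c2ccc(O)cc2)C1` gives 98.8%; compound 3 `CC(C)(C)C1=NN(c2ccc(Cl)cc2)C(c2ccc(Br)cc2)C1` gives 39%, all in an assay on isolated protein for inhibition of protein kinase C zeta type (Homo sapiens), with a stated time of 4 min, tested at 62.5 uM; on this read-out lower numbers stand for less inhibition and higher numbers for more inhibition at the one concentration tested (going by the name of the read-out).

On these numbers compound 3 stands lowest of the three: compound 1 is nearest, and compound 2 furthest, both beyond the scatter. Compound 4 `CC(C)(C)C1=NN(c2ccc(Cl)cc2)C(c2ccc(O)c(F)c2)C1` differs from compound 3 in one place: 3-fluoro-4-hydroxyphenyl in place of 4-bromophenyl on a saturated ring carbon. Among the compounds with values here, no measured step changes the group on that saturated ring carbon; the one measured step, a number 27.8 percentage points higher from compound 1 to compound 2 (beyond the scatter), alters the ring on the amine nitrogen instead. Compounds 1 and 2, which carry a hydroxyphenyl on the saturated carbon, both give more inhibition than compound 3. Compound 4 is therefore expected to rise, a number 31 percentage points higher from compound 3 to compound 4 (beyond the scatter), to an estimated 70% with a range from 45% to 95%.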

Compound 4, a percentage reported as inhibition, at one concentration (the size of the read-out at that concentration, not a potency): 98.5%
For compound 4 the middle estimate is 28.5 percentage points below the measured one, and the stated range ends below it.
By their numbers in this assay, from the lowest: compound 3; then compound 1; then compounds 4 and 2 (each within the scatter of the next).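

This is the first change shown at the saturated ring carbon, and in this assay 3-fluoro-4-hydroxyphenyl in place of 4-bromophenyl gives a number 59.5 percentage points higher from compound 3 to compound 4 (beyond the scatter), with the 4-chlorophenyl group on the ring nitrogen held fixed. The group on this carbon can therefore move the read-out by a large step on its own. No measurement at hand accounts for the rise.

The compounds shown do not separate the hydroxy group from the fluorine, as both enter together. As far as these compounds go, whether an amine, a carboxylic acid or a methoxy group could stand in for the hydroxy group remains open.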